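A few compounds are considered here, and "the series" means these few. Any claim that something is new, unique, unknown or untested is made for them only; others in the source may bear on it.

Compound 1 `O=C(Nc1ccc(F)cc1F)c1cncc(N2CC3CC(C2)N3)c1`: 50 nM
Compound 2 `O=C(Nc1ccc(F)cc1)c1cncc(N2CC3CC(C2)N3)c1`: 81 nM

Within the data shown here, in an assay on cells for displacement of a labelled ligand from Neuronal acetylcholine receptor; alpha3/beta4 (Homo sapiens) (a higher number here means a weaker inhibitor, a lower number a stronger inhibitor), compound 2 sits within the scatter of compound 1, the only other measured compound, the step being a 1.6-fold higher number from compound 1 to compound 2 (0.21 log units; within the scatter). Compound 3 `O=C(Nc1ccccc1)c1cncc(N2CC3CC(C2)N3)c1` is not yet measured; it differs from compound 2 by hydrogen in place of fluoro on an aromatic carbon. Among the measured compounds shown here, the one measured step of the same kind, a 1.6-fold higher number from compound 1 to compound 2 (0.21 log units; within the scatter), stayed within the scatter, so for compound 3 at most a small rise in this assay is expected, likely none beyond the scatter. Compound 3 is therefore estimated at 110 nM, with a range of 50 nM to 250 nM, an expected step of a 1.4-fold higher number from compound 2 to compound 3 (0.13 log units; within the scatter).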

Compound 3, inhibition constant: 192 nM
The estimate for compound 3 lay 1.7-fold (0.24 log units) below the measured number; measured number inside the range.
By their numbers in this assay, from the lowest: compounds 1 and 2 (each within the scatter of the next); then compound 3.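

Losing the last fluoro matters more than the earlier step suggested: in this assay, going from 4-fluorophenyl to phenyl gives a 2.4-fold higher number from compound 2 to compound 3 (0.37 log units; beyond the scatter), the first single swap of fluoro for hydrogen that lies beyond the scatter. Phenyl in place of 2,4-difluorophenyl gives a 3.8-fold higher number from compound 1 to compound 3 (0.58 log units; beyond the scatter), so having fluoro on this ring counts here, though the size of the step stays modest. Nothing measured here explains this difference.

As far as these compounds go, whether chloro, methyl or methoxy at this place would serve as well as fluoro stays open.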